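A few compounds are considered here, and "the series" means these few. Any claim that something is new, unique, unknown or untested is made for them only; others in the source may bear on it.

The series shares one core, carrying an amide and a benzyl group whose terminal aryl varies. Compound 1 `COC(=O)/C=C/c1cccc(N(Cc2ccc(/C=C/c3cccc(F)c3)cc2)C(=O)C(C)C)c1` bears a 2-(3-fluorophenyl)ethenyl group and an isobutyryl amide; in an assay on isolated protein with Bile acid receptor (Homo sapiens) as the target (on this read-out lower numbers stand for an effect already at smaller amounts and higher numbers for an effect only at larger amounts of compound), compound 1 gives 71 nM. Compound 2 `COC(=O)/C=C/c1cccc(N(Cc2ccc(-c3ccc(F)c(Cl)c3)cc2)C(=O)C2CCCCC2)c1` combines a 3-chloro-4-fluorophenyl group with a cyclohexyl amide, and compound 2 gives 66 nM. Compound 3 `COC(=O)/C=C/c1cccc(N(Cc2ccc(-c3ccc(OC(F)(F)F)cc3)cc2)C(=O)C(C)C)c1` keeps the isobutyryl amide of compound 1 but carries 4-(trifluoromethoxy)phenyl, and compound 3 gives 219 nM, the highest of the three numbers. For the measured compounds named here, the one single-point step available, a 3.1-fold higher number from compound 1 to compound 3 (0.49 log units; beyond the scatter), shows that exchanging the ethenyl-linked aryl for the trifluoromethoxyphenyl costs a modest amount.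

Compound 4 `COC(=O)/C=C/c1cccc(N(Cc2ccc(-c3ccc(F)c(Cl)c3)cc2)C(=O)C(C)C)c1` is reached from compound 3 by 3-chloro-4-fluorophenyl in place of 4-(trifluoromethoxy)phenyl on an aromatic carbon. Going by the values given here, no measured step covers this exact exchange; compound 2 carries the same 3-chloro-4-fluorophenyl group but differs in the amide as well, so its value can only hint. Since compound 2 gives 66 nM and compound 1 gives 71 nM, both well below compound 3, it is expected that the number for compound 4 will fall again, by roughly a 2.9-fold lower number from compound 3 to compound 4 (0.47 log units; beyond the scatter). Compound 4 is therefore estimated at 75 nM, with a likely range from 30 nM to 190 nM.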

Compound 4, half-maximal effective concentration: 129 nM
Estimate against measurement, compound 4: 1.7-fold (0.24 log units) below, and the stated range covers the measured number.
By their numbers in this assay, from the lowest: compounds 2, 1, 4 and 3 (each within the scatter of the next, the first and the last beyond it).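

In this assay, placing 3-chloro-4-fluorophenyl on this aromatic carbon in place of 4-(trifluoromethoxy)phenyl gives a step that cannot be told from the scatter (a 1.7-fold lower number from compound 3 to compound 4 (0.23 log units; within the scatter)), and the same holds for its exchange with 2-(3-fluorophenyl)ethenyl (a 1.8-fold higher number from compound 1 to compound 4 (0.26 log units; within the scatter)). Compound 4 therefore sits within the scatter of both neighbours, even though the step joining those two lies beyond it (a 3.1-fold higher number from compound 1 to compound 3 (0.49 log units; beyond the scatter)), so this terminal group cannot be assigned to either side of that gap. For the compounds shown here, compound 4 also provides the first comparison that changes only the amide, and isopropyl in place of cyclohexyl on the carbonyl carbon likewise stays within the scatter (a 2.0-fold higher number from compound 2 to compound 4 (0.29 log units; within the scatter)), though this rests on a single pair with one terminal aryl group.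

No information is available to explain any of these steps. The compounds shown leave open whether a carboxylic acid in place of the methyl ester, or an amine on the terminal aryl ring, would shift the number beyond the scatter.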